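Urea chain to ring in the sulfonate series

A few compounds are considered here, and "the series" means these few. Any claim that something is new, unique, unknown or untested is made for them only; others in the source may bear on it.

Compound 2 `CCCCCNC(=O)Nc1ccc(S(=O)(=O)Oc2ccccc2C(C)C)cc1` gives 4900 nM in a functional assay on HT-29 cells (Homo sapiens) for antiproliferative activity, read by sulforhodamine B assay, with a stated time of 48 h (on this read-out lower numbers stand for stronger inhibition and higher numbers for weaker inhibition), the lower of the two numbers shown; compound 1 `CC(C)C(=O)Nc1ccc(S(=O)(=O)Oc2ccccc2C(C)C)cc1` gives 14000 nM. Within the data shown here, the only measured step is a 2.9-fold lower number from compound 1 to compound 2 (0.46 log units; beyond the scatter), which changes the group on the carbonyl carbon and does not bear on a chain-to-ring swap at the urea nitrogen. Compound 3 `CC(C)c1ccccc1OS(=O)(=O)c1ccc(NC(=O)NC2CCCC2)cc1` differs from compound 2 by cyclopentyl in place of pentyl on an amide-type nitrogen. Among the measured compounds shown here, with no measured step of this kind, no shift beyond the scatter is expected, so for compound 3 the estimate is 4900 nM, within 2000 nM to 12000 nM. The step of no change at the digits printed from compound 2 to compound 3 (within the scatter) is expected to stay within the scatter.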

Compound 3, half-maximal inhibitory concentration: 7400 nM
The estimate for compound 3 lay 1.5-fold (0.18 log units) below the measured number; the range from low to high includes it.
By their numbers in this assay, from the lowest: compounds 2, 3 and 1 (each within the scatter of the next, the first and the last beyond it).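

In this assay, cyclopentyl in place of pentyl on the amide-type nitrogen gives a 1.5-fold higher number from compound 2 to compound 3 (0.18 log units; within the scatter), so at this position the ring and the open chain cannot be told apart. Cyclopentylamino in place of isopropyl on the carbonyl carbon gives a 1.9-fold lower number from compound 1 to compound 3 (0.28 log units; within the scatter), which does not separate from the scatter, whereas pentylamino does in a 2.9-fold lower number from compound 1 to compound 2 (0.46 log units; beyond the scatter). No available evidence accounts for these steps.

Open, going by these compounds, is whether cyclohexyl or a shorter chain such as propyl on the same nitrogen would stay as close to compound 2. Also open, on these data alone, is what an amine on the cyclopentyl ring would do.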